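Swapping an Aminophenyl for a Difluorophenyl on Vero Cells

The source may report more compounds than this note shows. Statements on the series, on what has been measured and on what is new or still open speak of the compounds shown alone.

Compound 1, `CCOC(=O)c1cc(-c2cccc(OCc3cccc(N)c3)c2)on1`: > 128000 nM
Compound 2, `CCOC(=O)c1cc(-c2cccc(OCc3ccccc3C(F)(F)F)c2)on1`: > 128000 nM
Compound 3, `CCOC(=O)c1cc(-c2cccc(OCc3cccc(C(F)(F)F)c3F)c2)on1`: > 128000 nM

These three compounds share one core and differ only in the group carried on a saturated chain carbon bound to an oxygen on an aromatic ring. In an ADME assay on Vero cells (Chlorocebus sabaeus) for cytotoxicity, with a stated time of 72 h (on this read-out lower numbers stand for stronger inhibition and higher numbers for weaker inhibition), compound 1 gives > 128000 nM, which is a limit of the assay rather than a number. Compound 2 also reaches only a limit, > 128000 nM. Compound 3 likewise stops at a limit, > 128000 nM. Within the data shown here, compound 1 therefore stands at the limit of > 128000 nM in this assay, at which 3 of the 3 values shown sit, and no measured step between compounds exists for comparison. Compound 4, `CCOC(=O)c1cc(-c2cccc(OCc3cc(F)cc(F)c3)c2)on1`, has not yet been tested in this assay. It differs from compound 1 by 3,5-difluorophenyl in place of 3-aminophenyl on a saturated chain carbon bound to an oxygen on an aromatic ring. With all shown values sitting at one limit, the step that the limit leaves unreadable from compound 1 to compound 4 is expected to be none beyond the scatter. Compound 4 is expected to give 200000 nM, in the range 90000 nM to 600000 nM, most likely reported again as a limit.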

Compound 4, half-maximal inhibitory concentration: > 128000 nM
Compound 4: no number, only a limit; the forecaster's own chance of this, stated with the estimate: 90%; the middle value is on the limit's open side.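

Among these compounds, compound 1 and compound 4 both end at a limit, so no step between them can be read: the limit of > 128000 nM in this assay, at which 4 of the 4 values shown sit.
Whether any of these groups changes the result in this assay at concentrations past that limit stays open in the compounds shown.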